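The compounds below may be only part of what the source reports. "The series", "measured", "known", "first", "only" and "open" are said of these compounds alone.

Of the compounds shown here, two have been measured so far. Compound 1, `O=C(/C(=C\c1c(-c2ccccc2)[nH]c2ccccc12)S(=O)(=O)c1ccccc1)c1ccccc1`, is the weaker of the two in a functional assay on KM12 cells (Homo sapiens) for inhibition, read by sulforhodamine B assay, with a stated time of 48 h (a lower number here means a stronger inhibitor of growth, a higher number a weaker inhibitor of growth), where compound 1 gives 5100 nM. Compound 2, `COc1ccc(-c2[nH]c3ccc(OC)cc3c2C=C(C#N)C#N)cc1`, gives 590 nM in this assay, a markedly lower number than compound 1. The next compound, compound 3, `N#C/C(=C\c1c(-c2ccccc2)[nH]c2ccccc12)S(=O)(=O)c1ccccc1`, shares the core of compound 1 and differs from it in one place: cyano in place of benzoyl on a double-bonded chain carbon bound to a double-bonded chain carbon and a sulfonyl sulfur. Nothing measured yet shows what such a change does on this core, so no step can be read from the data. Compound 2 carries a cyano group of its own and shows the lower number of the two, but it also differs from compound 1 elsewhere, so it is at best a hint. A modest move toward a lower number is expected for compound 3, near the edge of the scatter, as a 2.0-fold lower number from compound 1 to compound 3 (0.31 log units; beyond the scatter). Compound 3 is estimated at 2500 nM, between 800 nM and 8000 nM.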

Compound 3, concentration for 50% growth inhibition: 652 nM
For compound 3 the middle estimate is 3.8-fold (0.58 log units) above the measured one; measured number below the stated range.
By their numbers in this assay, from the lowest: compounds 2 and 3 (each within the scatter of the next); then compound 1.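

Swapping benzoyl for cyano on the double-bonded chain carbon bound to a double-bonded chain carbon and a sulfonyl sulfur gives a 7.8-fold lower number from compound 1 to compound 3 (0.89 log units; beyond the scatter) in this assay. Among the compounds shown here, this is the first direct reading of a change at this place, and it shows that the group there affects the number on the shared core. The benzoyl group and its aromatic ring are not needed for growth inhibition here, since the much smaller cyano group goes with the lower number.

As far as these compounds go, whether another group at this place, such as a carboxylic acid, an amide or a methyl group, would lower the number further remains open, as does whether the same swap would have a similar effect on a different core. No measurement shown here accounts for the drop.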